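Replacing thiophen-2-yl with pyridin-3-yl in compound 3

The source may report more compounds than this note shows. Statements on the series, on what has been measured and on what is new or still open speak of the compounds shown alone.

Within the data shown here, in a functional assay on U-937 cells (Homo sapiens), read by cAMP accumulation (a lower number here means that less compound is needed, a higher number that more compound is needed for the effect), compound 3 `CCc1nn(C2CCCC2)c2c1CCN(c1cccs1)C2=O` gives 1 nM, the lowest of the three numbers measured so far. Compound 2 `CCc1nn(C2CCCC2)c2c1CCN(c1cccc(OC)c1)C2=O` gives 330 nM, and compound 1 `CCc1nn(-c2ccc(F)cc2)c2c1CCN(c1ccccc1)C2=O` gives 880 nM. Compound 4 `CCc1nn(C2CCCC2)c2c1CCN(c1cccnc1)C2=O` has not been measured. It carries pyridin-3-yl in place of thiophen-2-yl on an amide-type nitrogen in a ring. One measured step changes that same place, a 330-fold lower number from compound 2 to compound 3 (2.52 log units; beyond the scatter), which is large and beyond the scatter. Compound 4 again carries a six-membered aromatic ring there, as compound 2 does at 330 nM, so a large rise in this assay is expected, probably smaller than that measured step. Among the measured compounds shown here, no measured compound carries pyridin-3-yl, so the uncertainty is wide. The expected step is a 60-fold higher number from compound 3 to compound 4 (1.78 log units; beyond the scatter). Compound 4 is estimated at 60 nM, with an expected range of 8 nM to 450 nM.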

Compound 4, half-maximal effective concentration: 17 nM
Beside the measured number, compound 4's estimate is 3.5-fold (0.55 log units) above it; low and high end bracket the measured number.
By their numbers in this assay, from the lowest: compound 3; then compound 4; then compound 2; then compound 1.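

In this assay, thiophen-2-yl on the amide-type nitrogen in a ring still gives the lowest number, with a 17-fold higher number from compound 3 to compound 4 (1.23 log units; beyond the scatter) on moving to pyridin-3-yl. A six-membered aromatic ring alone does not restore the number of compound 2, however: a 19-fold lower number from compound 2 to compound 4 (1.29 log units; beyond the scatter) separates the two six-membered groups, so the outcome depends on more than ring size. Nothing shown here explains these differences. Going by these compounds, it remains open whether furan-2-yl or pyridin-4-yl would fall nearer to thiophen-2-yl or to pyridin-3-yl, and whether this order holds with other groups elsewhere on the shared core.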